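A Trifluoromethyl Change at the Cytotoxicity Limit

The source may report more compounds than this note shows. Statements on the series, on what has been measured and on what is new or still open speak of the compounds shown alone.

In an ADME assay on Huh-7 cells (Homo sapiens) for cytotoxicity, with a stated time of 72 h (a higher number here means that more compound is tolerated, a lower number that less compound is tolerated), compound 1 (`CC(C)CCn1nc(C2=CCCC2)c(O)c(C2=NS(=O)(=O)c3cc(NS(C)(=O)=O)ccc3N2)c1=O`) gives > 1000 nM, which is a limit. Compound 2 (`CC(C)=Cc1nn(CCC(C)C)c(=O)c(C2=NS(=O)(=O)c3cc(NS(C)(=O)=O)ccc3N2)c1O`) gives > 1000 nM, which is also a limit, and so it has no exact value. Within the data shown here, the one measured step is a step that the two limits leave unreadable from compound 1 to compound 2, and both compounds stand at the limit of > 1000 nM in this assay, at which 2 of the 2 values shown sit. Compound 3 (`C/C(=C\c1nn(CCC(C)C)c(=O)c(C2=NS(=O)(=O)c3cc(NS(C)(=O)=O)ccc3N2)c1O)C(F)(F)F`) differs from compound 2 by 2-(trifluoromethyl)prop-1-en-1-yl in place of 2-methylprop-1-en-1-yl on an aromatic carbon. With no readable step to draw on, no change beyond the scatter is expected in this assay, in either direction. The expected step is a step that the limit leaves unreadable from compound 2 to compound 3. Compound 3 is estimated at 1500 nM, with an expected range of 800 nM to 5000 nM.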

Compound 3, half-maximal cytotoxic concentration: > 33000 nM
Compound 3 ended at the assay's limit (the forecaster's own chance of this, stated with the estimate: 85%); at least 22-fold (1.34 log units) between middle value and limit.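

Among these compounds, compound 1, compound 2 and compound 3 all sit at limits, so no step among them can be read. The compounds shown leave open where each half-maximal cytotoxic concentration truly lies, and whether the 2-(trifluoromethyl)prop-1-en-1-yl group shifts it at all.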